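The source may hold more compounds than are shown below. What is called first, only, known or untested is meant among the compounds shown, and "the series" means these compounds.

Compound 1 `CCn1ccnc1-c1cc(OC)c(OC)c(OC)c1` carries an ethyl group on the aromatic nitrogen of the shared core. In a functional assay on T47D cells (Homo sapiens) for antiproliferative activity, read by MTT assay, with a stated time of 72 h (a higher number here means a weaker inhibitor, a lower number a stronger inhibitor), compound 1 gives only a limit, > 100000 nM. Compound 3 `COc1cc(OC)cc(-n2ccnc2-c2cc(OC)c(OC)c(OC)c2)c1` likewise gives only a limit in this assay, > 100000 nM. Among the measured compounds shown here, compound 2 `COc1cc(-c2nccn2-c2ccc3cc[nH]c3c2)cc(OC)c1OC` gives 18000 nM in this assay, the one measured number in the set. Compound 1 thus stands at the limit of > 100000 nM in this assay, at which 2 of the 3 values shown sit, with no number of its own to anchor a step. For the measured compounds named here, no two measured compounds differ in a single place, so no measured step is available for comparison.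

Compound 4 `COc1cc(-c2nccn2-c2ccc(F)cc2)cc(OC)c1OC` is the next case: 4-fluorophenyl in place of ethyl on an aromatic nitrogen. Going by the values given here, the two values at the limit and the single number from compound 2 give only a rough sense of what an aryl group on that nitrogen does. For compound 4 the expectation is a move toward stronger inhibition, with the step estimated at an at least 3.3-fold lower number from compound 1 to compound 4 (0.52 log units; beyond the scatter), while the chance that this assay again reports only a limit stays considerable. Compound 4 is estimated at 30000 nM in this assay, with a range of 8000 nM to 100000 nM.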

Compound 4, half-maximal inhibitory concentration: > 100000 nM
Compound 4 was reported as a limit (the forecaster's own chance of this, stated with the estimate: 40%); at least 3.3-fold (0.52 log units) between middle value and limit.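

Compound 1 and compound 4 both stand only as limits in this assay, so no step can be read between them: the limit of > 100000 nM in this assay, at which 3 of the 4 values shown sit.

The compounds shown leave open whether 4-fluorophenyl in place of ethyl on an aromatic nitrogen changes inhibition at all, and in which direction.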